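The compounds below may be only part of what the source reports. "The series", "measured", "known", "first", "only" and "open" are said of these compounds alone.

Measured so far:
- compound 1 `c1coc(-c2ccccc2NCC2=NCCN2)c1`: 16.2 nM
- compound 2 `Cc1nc(-c2ccccc2NCC2=NCCN2)cs1`: < 5020 nM

Among the compounds with values here, compound 1 is the only compound of the series with a numerical value in a functional assay for activation of Alpha-1D adrenergic receptor (Homo sapiens); a higher number here means that more compound is needed for the effect, a lower number that less compound is needed; it gives 16.2 nM. For compound 2 the assay gives only a limit, < 5020 nM, and not a number. The step that the limit leaves unreadable from compound 1 to compound 2 therefore cannot be sized; what remains readable is the limit of < 5020 nM in this assay, at which 1 of the 2 values shown sits.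

Compound 3 `Cc1nc(-c2ccccc2NCC2=NCCN2)no1` is not yet measured. It differs from compound 1 by 5-methyl-1,2,4-oxadiazol-3-yl in place of furan-2-yl on an aromatic carbon. Within the data shown here, the one measured step that bears on it, 2-methyl-1,3-thiazol-4-yl in place of furan-2-yl, ended at a limit, so its true size is unknown beyond being a loss. A second five-membered ring with several hetero atoms in the same place is expected to move in the same direction, by a large step. Compound 3 is estimated at 3000 nM (range 300 nM to 20000 nM), meaning an expected step of a 190-fold higher number from compound 1 to compound 3 (2.27 log units; beyond the scatter), with a fair chance that only a limit is returned.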

Compound 3, half-maximal effective concentration: < 5020 nM
Compound 3 was reported as a limit; the forecaster's own chance of this, stated with the estimate: 55%; the middle value lies beyond the limit too.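

Within the data shown here, compound 3, like compound 2, returns only a limit, so no step from compound 1 to compound 3 or from compound 2 to compound 3 can be read. Still open is how far each lies from compound 1, and whether they differ from each other, with both resting on one reading: the limit of < 5020 nM in this assay, at which 2 of the 3 values shown sit.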